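Fluoro on the shared core: estimate for compound 4

The source may hold more compounds than are shown below. What is called first, only, known or untested is meant among the compounds shown, and "the series" means these compounds.

Compound 1 `CCNC(=O)c1cc(Oc2ccc(NC(=O)c3cc4cccnc4n(-c4ccccc4)c3=O)cc2)ccn1` in a functional assay on A549 cells (Homo sapiens) for antiproliferative activity, read by MTT assay, with a stated time of 72 h (a lower number here means a stronger inhibitor, a higher number a weaker inhibitor), gives 160 nM. Compound 2 `CCNC(=O)c1cc(Oc2ccc(NC(=O)c3cc4cccnc4n(-c4ccc(F)cc4)c3=O)cc2)ccn1` carries fluoro in place of hydrogen on an aromatic carbon and gives 120 nM, a step of a 1.3-fold lower number from compound 1 to compound 2 (0.12 log units; within the scatter). Compound 3 `CCCNC(=O)c1cc(Oc2ccc(NC(=O)c3cc4cccnc4n(-c4ccccc4)c3=O)cc2)ccn1` differs from compound 1 by methyl in place of hydrogen on a saturated chain carbon, two bonds along the chain from an amide-type nitrogen; in this assay compound 3 gives 95 nM, a step of a 1.7-fold lower number from compound 1 to compound 3 (0.23 log units; within the scatter). Compound 4 `CCCNC(=O)c1cc(Oc2ccc(NC(=O)c3cc4cccnc4n(-c4ccccc4F)c3=O)cc2)ccn1` is not yet measured and differs from compound 3 by fluoro in place of hydrogen on an aromatic carbon. This is the same kind of change as that from compound 1 to compound 2, not the same: there the fluoro sits para to a large group, here ortho to a large group. Since the earlier step of a 1.3-fold lower number from compound 1 to compound 2 (0.12 log units; within the scatter) stayed within the scatter, a step of about a 1.1-fold lower number from compound 3 to compound 4 (0.02 log units; within the scatter) is expected for compound 4, with the ortho placement adding uncertainty. Compound 4 is estimated at 90 nM, expected between 40 nM and 220 nM.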

Compound 4, half-maximal inhibitory concentration: 150 nM
Estimate against measurement, compound 4: 1.7-fold (0.22 log units) below; low and high end bracket the measured number.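

In this assay, fluoro in place of hydrogen on the core of compound 3 gives a 1.6-fold higher number from compound 3 to compound 4 (0.20 log units; within the scatter), so this change has no effect here that stands clear of the scatter. Set beside the earlier step, the new one does not show that the core alters the outcome of the change: the same change on two cores in this assay, a 1.3-fold lower number (0.12 log units; within the scatter) from compound 1 to compound 2 and a 1.6-fold higher number (0.20 log units; within the scatter) from compound 3 to compound 4, 2.1-fold (0.32 log units) apart, within the scatter of two such steps. Nor does this show that the change carries over unaltered, since the fluoro of compound 4 sits ortho to a large group and that of compound 2 elsewhere on the ring, so core and place are not separated.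

Open, as far as these compounds go, is how 2-fluorophenyl behaves on the core of compound 1. Also open, from the compounds shown here alone, is whether chloro or methoxy on that ring, or a butyl chain or an amine on the amide nitrogen, gives a step beyond the scatter.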